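A Second Chlorine on the Aromatic Ring of Compound 3

This account rests on a few compounds, and the source may have more. Where it says the series, first, only, none or still open, it means among the compounds named here.

Compound 1 `N#C/C(=C\N1CCN(C(=O)c2ccco2)C1=S)C(=O)Nc1ccc(Cl)cc1`: 13100 nM
Compound 2 `N#C/C(=C\N1CCN(C(=O)c2ccco2)C1=S)C(N)=O`: 19200 nM
Compound 3 `O=CN1CCN(c2ccc(Cl)cc2)C1=S`: 16800 nM

All three numbers come from a functional assay on RXF 393 cells (Homo sapiens) for inhibition, read by sulforhodamine B assay, with a stated time of 48 h (a lower number here means a stronger inhibitor of growth, a higher number a weaker inhibitor of growth), and lie within the scatter of one another, so compound 3 can be placed neither above nor below compound 1 or compound 2. Compound 4 `O=CN1CCN(c2ccc(Cl)c(Cl)c2)C1=S` differs from compound 3 by chloro in place of hydrogen on an aromatic carbon. Within the data shown here, the only measured step, a 1.5-fold higher number from compound 1 to compound 2 (0.17 log units; within the scatter), swaps a whole aryl group for hydrogen on a nitrogen and so is a different kind of change; no measured pair adds a chloro to a ring. Little guidance therefore exists, and the expected step is a 1.1-fold lower number from compound 3 to compound 4 (0.05 log units; within the scatter), none beyond the scatter. Compound 4 is estimated at 15000 nM, expected between 7000 nM and 32000 nM.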

Compound 4, concentration for 50% growth inhibition: 17500 nM
Estimate against measurement, compound 4: 1.2-fold (0.07 log units) below; the range from low to high includes it.
By their numbers in this assay, from the lowest: compounds 1, 3, 4 and 2 (each within the scatter of the next).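

In this assay, among these compounds, adding a chloro group to the aromatic ring, ortho to the chloro group already there, gives a 1.0-fold higher number from compound 3 to compound 4 (0.02 log units; within the scatter) and is the first measured case of this change. At this ring position, the second chlorine leaves the two compounds indistinguishable in this test. No measurement shown offers an explanation for this result.

As far as these compounds go, whether an amine or a carboxylic acid on this same carbon would give a step beyond the scatter remains open. So does the outcome of placing a chloro group elsewhere on the ring.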